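Benzyl to isopropyl on the acylurea nitrogen

The compounds below may be only part of what the source reports. "The series", "measured", "known", "first", "only" and "open" are said of these compounds alone.

Measured so far:
compound 1 `CC(C)c1cccc(C(C)C)c1NC(=O)NC(=O)N(c1ccccc1)c1ccccc1` — 340 nM
compound 2 `CC(C)c1cccc(C(C)C)c1NC(=O)NC(=O)N(Cc1ccccc1)Cc1ccccc1` — 1040 nM

In an assay on microsomes from intestine for inhibition of acyl-CoA:cholesterol acyltransferase (Oryctolagus cuniculus) (on this read-out higher numbers stand for weaker inhibition and lower numbers for stronger inhibition), compound 2 gives 1040 nM, the higher of the two numbers; compound 1 gives 340 nM, a gap beyond the scatter. Compound 3 `CC(C)c1cccc(C(C)C)c1NC(=O)NC(=O)N(Cc1ccccc1)C(C)C` differs from compound 2 by isopropyl in place of benzyl on an amide-type nitrogen. Among the measured compounds shown here, no comparable step between measured compounds exists, so the direction is open. A step of about a 1.4-fold higher number from compound 2 to compound 3 (0.16 log units; within the scatter) is expected, towards a slightly higher number. In this assay compound 3 is estimated at 1500 nM, range 500 nM to 5000 nM.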

Compound 3, half-maximal inhibitory concentration: 750 nM
Beside the measured number, compound 3's estimate is 2.0-fold (0.30 log units) above it, within the range that was stated.
By their numbers in this assay, from the lowest: compound 1; then compounds 3 and 2 (each within the scatter of the next).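

In this assay, among the compounds shown here, the step of a 1.4-fold lower number from compound 2 to compound 3 (0.14 log units; within the scatter) gives the first reading at this position: isopropyl in place of benzyl on the amide-type nitrogen is tolerated. One six-membered aromatic ring leaves with the benzyl, yet the two numbers cannot be told apart, so that ring is not required to keep the number in this range. No measured evidence bears on why this is so.

Going by these compounds, whether the remaining benzyl of compound 3 can also give way to isopropyl stays open. So does the outcome with methyl, a longer chain or an amine on this nitrogen.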